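The compounds below may be only part of what the source reports. "The series", "measured", "known", "first", "only" and "open" are said of these compounds alone.

Compound 3 `COc1ccc(F)cc1CNCCCNc1ccnc2cc(-c3ccc(F)cc3)ccc12` gives 9.47 in a physicochemical assay for acid dissociation. Compound 1 `COc1ccc(-c2ccc3c(NCCCNCc4cccc(OC)c4O)ccnc3c2)cc1` gives 9.47 and compound 2 `COc1ccc(F)cc1CNCCCNc1ccnc2cc(C3CCCCC3)ccc12` gives 9.47, so compound 3 stands level with both at the digits shown. Within the data shown here, the one measured single step, from compound 2 to compound 3, reads no change at the digits printed from compound 2 to compound 3 (within the scatter) for 4-fluorophenyl in place of cyclohexyl on an aromatic carbon.

Compound 4 `COc1ccc(-c2ccc3c(NCCCNCc4cc(F)ccc4OC)ccnc3c2)cc1` is not yet measured. It differs from compound 3 by methoxy in place of fluoro on an aromatic carbon. Among the measured compounds shown here, no measured step covers this exact exchange. Two observations bear on it: the step from compound 2 to compound 3 gave no change at the digits printed from compound 2 to compound 3 (within the scatter) when the group on that aromatic carbon was swapped, and compound 1, which already carries the 4-methoxyphenyl that enters here, gives 9.47, the same value as compound 3. The step in this assay from compound 3 to compound 4 is therefore expected to be no change at the digits printed from compound 3 to compound 4 (within the scatter), nothing beyond the scatter. Compound 4 is expected to give 9.47, with a range from 9.2 to 9.75.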

Compound 4, acid dissociation constant: 9.47
The estimate for compound 4 equals the measured number at the digits printed; measured number inside the range.
By their numbers in this assay, from the lowest: compounds 1, 2, 3 and 4 (each within the scatter of the next).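

In this assay, the exchange of 4-fluorophenyl to 4-methoxyphenyl, with methoxy in place of fluoro on an aromatic carbon para to a large group, reads no change at the digits printed from compound 3 to compound 4 (within the scatter), so a second aryl substituent now joins the earlier cyclohexyl exchange as leaving this read-out in place. Direct replacement of cyclohexyl by 4-methoxyphenyl reads no change at the digits printed from compound 2 to compound 4 (within the scatter), and 5-fluoro-2-methoxyphenyl in place of 2-hydroxy-3-methoxyphenyl on a saturated chain carbon bound to an amine nitrogen reads no change at the digits printed from compound 1 to compound 4 (within the scatter), so the read-out also holds through a change at a second site. Nothing further is available to explain these readings.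

Still open, as far as these compounds go, is whether an amine or a carboxylic acid on this aromatic ring would shift the read-out beyond the scatter. The same question stands for a longer chain in place of the shared one.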